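The source may hold more compounds than are shown below. What is called first, only, known or untested is meant among the compounds shown, and "the series" means these compounds.

Measured compounds:
Compound 1 `Cn1cncc1CN1CC(N(CC2CCN(C(=O)c3ccc(Cl)cc3)CC2)S(=O)(=O)c2ccccn2)Cc2cc(C#N)ccc21` — 0.5 10^-6 cm/s
Compound 2 `Cn1cncc1CN1CC(N(CC2CCN(C(=O)c3ccccc3)CC2)S(=O)(=O)c2ccccn2)Cc2cc(C#N)ccc21` — 0.5 10^-6 cm/s

In an ADME assay on Caco-2 cells (Homo sapiens) for permeability, in the apical to basolateral direction (a higher number here means that the compound crosses the layer faster, a lower number that the compound crosses the layer more slowly), compound 2 gives 0.5 10^-6 cm/s, level with compound 1 at the digits shown. Going by the values given here, the only measured step, no change at the digits printed from compound 1 to compound 2 (within the scatter), shows that removing the chloro left the read-out unchanged. Compound 3 `CC(C)S(=O)(=O)N1CCC(CN(C2Cc3cc(C#N)ccc3N(Cc3cncn3C)C2)S(=O)(=O)c2ccccn2)CC1` differs from compound 2 by isopropylsulfonyl in place of benzoyl on an amine nitrogen in a ring. Among the compounds with values here, no measured step covers an exchange of this kind, so the single flat step offers little guidance beyond showing that both measured compounds sit at the same low level. A modest step, a 1.2-fold higher number from compound 2 to compound 3 (0.08 log units; within the scatter), is expected, in either direction within the scatter. Compound 3 is estimated at 0.6 10^-6 cm/s, with a range from 0.2 10^-6 cm/s to 1.8 10^-6 cm/s.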

Compound 3, apparent permeability: 0.1 10^-6 cm/s
Compound 3: middle estimate off by 6.0-fold (0.78 log units), on the high side; measured number below the stated range.
By their numbers in this assay, from the lowest: compound 3; then compounds 1 and 2 (each within the scatter of the next).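

In this assay, the amine nitrogen in a ring proves sensitive to what it carries, even though removing the chloro changed nothing: isopropylsulfonyl in place of benzoyl gives a 5.0-fold lower number from compound 2 to compound 3 (0.70 log units; beyond the scatter) and, in place of (4-chlorophenyl)carbonyl, gives a 5.0-fold lower number from compound 1 to compound 3 (0.70 log units; beyond the scatter) as well. Exchanging the whole group therefore matters here in a way that the chloro alone did not. No measurement shown explains this drop. On these data alone, it remains open which part of the exchange carries the step, the sulfonyl or the lost aromatic ring; phenylsulfonyl or isobutyryl on that nitrogen would separate the two.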